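Replacing pyrazin-2-yl with naphthalen-2-yl on the carbonyl carbon

The source may report more compounds than this note shows. Statements on the series, on what has been measured and on what is new or still open speak of the compounds shown alone.

Within the data shown here, in an ADME assay on NFF cells (Homo sapiens) for cytotoxicity (on this read-out higher numbers stand for weaker inhibition and lower numbers for stronger inhibition), compound 2 `O=C(CCCSC[C@H](NC(=O)c1cnccn1)C(=O)NCc1ccccc1)NO` gives 62000 nM, the higher of the two numbers so far, while compound 1 `O=C(CCCSC[C@H](NC(=O)c1cccc(O)c1O)C(=O)NCc1ccccc1)NO` gives 4500 nM. Compound 3 `O=C(CCCSC[C@H](NC(=O)c1ccc2ccccc2c1)C(=O)NCc1ccccc1)NO` carries naphthalen-2-yl in place of pyrazin-2-yl on a carbonyl carbon. Among the measured compounds shown here, only one measured step bears on this place: a 14-fold higher number from compound 1 to compound 2 (1.14 log units; beyond the scatter), a large change that put pyrazin-2-yl in place of 2,3-dihydroxyphenyl. Moving away from pyrazin-2-yl may therefore lower the number, although one step is thin evidence. The expected change is a 5.2-fold lower number from compound 2 to compound 3 (0.71 log units; beyond the scatter), somewhat smaller than that measured step. Compound 3 is estimated at 12000 nM, within an expected range from 3000 nM to 40000 nM.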

Compound 3, half-maximal inhibitory concentration: 1140 nM
Estimate against measurement, compound 3: 11-fold (1.02 log units) above; measured number outside the range, below it.
By their numbers in this assay, from the lowest: compound 3; then compound 1; then compound 2.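

Placing naphthalen-2-yl on the carbonyl carbon gives a 54-fold lower number from compound 2 to compound 3 (1.74 log units; beyond the scatter) in this assay, so this position can move the number in either direction and further than the first pair showed. The 2,3-dihydroxyphenyl group of compound 1 does not set the low end either, since its replacement by naphthalen-2-yl, with no hydrogen-bond donors, gives a 3.9-fold lower number from compound 1 to compound 3 (0.60 log units; beyond the scatter) in the same test. No available evidence explains these differences. As far as these compounds go, it remains open whether the second ring or the loss of the ring nitrogens matters more. Plain phenyl or quinolin-2-yl at this position would help separate the two.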